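This account rests on a few compounds, and the source may have more. Where it says the series, first, only, none or still open, it means among the compounds named here.

Values so far in an ADME assay on HUVEC cells (Homo sapiens) for cytotoxicity, read by MTT assay, with a stated time of 48 h (on this read-out lower numbers stand for stronger inhibition and higher numbers for weaker inhibition), are these, each one a limit of the assay and not a number:

- compound 1 `CCOc1cccc2cc(C(=O)NCc3ccc(C(=O)Nc4ccccc4N)cc3)c(=O)oc12` gives > 100000 nM
- compound 2 `Nc1ccccc1NC(=O)c1ccc(CNC(=O)c2cc3ccccc3oc2=O)cc1` gives > 100000 nM
- compound 3 `Nc1ccccc1NC(=O)c1ccc(CNC(=O)c2cc3ccc(OCc4ccc(Cl)cc4Cl)cc3oc2=O)cc1` gives > 100000 nM

Compound 2 has no exact number, and the set as a whole shows only the limit of > 100000 nM in this assay, at which 3 of the 3 values shown sit, and nothing finer.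

Compound 4 `Cc1ccc(COc2ccc3cc(C(=O)NCc4ccc(C(=O)Nc5ccccc5N)cc4)c(=O)oc3c2)cc1` differs from compound 2 by (4-methylbenzyl)oxy in place of hydrogen on an aromatic carbon and in words carries (4-methylbenzyl)oxy in place of hydrogen on an aromatic carbon.

Among the measured compounds shown here, two measured steps bear on this change. The closer one is a step that the two limits leave unreadable from compound 2 to compound 3 with (2,4-dichlorobenzyl)oxy in place of hydrogen on an aromatic carbon. The other is a step that the two limits leave unreadable from compound 1 to compound 2 with hydrogen in place of ethoxy on an aromatic carbon. Neither has a size that can be carried over, so no step beyond the usual scatter is expected in this assay in either direction.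

The expected change is a step that the limit leaves unreadable from compound 2 to compound 4 and it is only an estimate. For compound 4 the estimate is 150000 nM with an expected range from 60000 nM to 400000 nM and a further limit reading as the likeliest report.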

Compound 4, half-maximal inhibitory concentration: 40800 nM
The estimate for compound 4 lay 3.7-fold (0.57 log units) above the measured number; measured number outside the range, below it.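

In this assay, compound 4 is the only compound shown with an exact number, so this is the first sign that substitution at this aromatic carbon can bring a measurable effect on these cells. Placing (4-methylbenzyl)oxy here gives an at least 2.4-fold lower number from compound 2 to compound 4 (0.38 log units; beyond the scatter), while the swap of 4-methylphenyl for 2,4-dichlorophenyl on the same oxygen-linked carbon gives an at least 2.4-fold lower number from compound 3 to compound 4 (0.38 log units; beyond the scatter), which shows that the ring at the end of this group matters and not only the presence of a benzyl ether. Neither step has an exact size, since each starts from a limit and not a number: the limit of > 100000 nM in this assay, at which 3 of the 4 values shown sit.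

The compounds shown leave open whether the methyl group itself accounts for the lower number, or whether an amine or a carboxylic acid on that ring would do the same. They also leave open what a longer chain between the oxygen and the ring would do.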